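The source may report more compounds than this note shows. Statements on the series, on what has been measured and on what is new or still open speak of the compounds shown alone.

Two compounds share one core and differ only in the group carried on a nitrogen on an aromatic ring. Compound 1 `CC(C)c1ccc(-c2nc(SCc3cn(CC(=O)NC(=O)Nc4ccccn4)nn3)nc(Nc3ccc(F)cc3)c2C#N)cc1` carries a 4-fluorophenyl there; in a functional assay on MGC-803 cells (Homo sapiens) for inhibition, read by MTT assay, with a stated time of 72 h (a higher number here means a weaker inhibitor, a lower number a stronger inhibitor), compound 1 gives 17500 nM. Compound 2 `Cc1ccccc1Nc1nc(SCc2cn(CC(=O)NC(=O)Nc3ccccn3)nn2)nc(-c2ccc(C(C)C)cc2)c1C#N` carries a 2-methylphenyl instead; in this assay compound 2 gives 19000 nM. The step of a 1.1-fold higher number from compound 1 to compound 2 (0.04 log units; within the scatter) shows that exchanging one ring group for another on this nitrogen left the number essentially where it was. Compound 2 has the highest of the two numbers, yet its gap to compound 1 lies within the scatter, so no order between the two can be read from them.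

Compound 3 `CC(C)c1ccc(Nc2nc(SCc3cn(CC(=O)NC(=O)Nc4ccccn4)nn3)nc(-c3ccc(C(C)C)cc3)c2C#N)cc1` continues the same kind of exchange: 4-isopropylphenyl in place of 2-methylphenyl on a nitrogen on an aromatic ring. Going by the values given here, the only measured step that bears on this change is the one from compound 1 to compound 2, and it stayed within the scatter, so a further exchange of one ring group for another on the same nitrogen is expected to shift this assay by no more than the scatter. Compound 3 is therefore expected to give 18000 nM in this assay, with a range from 7000 nM to 45000 nM. The expected step is a 1.1-fold lower number from compound 2 to compound 3 (0.02 log units; within the scatter).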

Compound 3, half-maximal inhibitory concentration: 15800 nM
Compound 3: middle estimate off by 1.1-fold (0.06 log units), on the high side; measured number inside the range.
By their numbers in this assay, from the lowest: compounds 3, 1 and 2 (each within the scatter of the next).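

Replacing 2-methylphenyl with 4-isopropylphenyl on this nitrogen takes the group from 7 to 9 carbons and moves the ring's substituent to a different place, yet this assay shows a 1.2-fold lower number from compound 2 to compound 3 (0.08 log units; within the scatter) for this change. Isopropyl in place of fluoro on an aromatic carbon gives a 1.1-fold lower number from compound 1 to compound 3 (0.04 log units; within the scatter) and likewise leaves the number unmoved, so among these three compounds, the assay does not separate three differently substituted phenyl groups on this nitrogen. No measurement is available here to explain why these exchanges leave the number unmoved.

Going by these compounds, all three groups on this nitrogen are carbon-only aromatic rings, so it remains open whether an amine or a carboxylic acid on that ring, or a simple ethyl chain in place of the ring, would shift the number beyond the scatter. The rest of the molecule is the same in all three compounds, which leaves open how much changes elsewhere, such as replacing the isopropyl on the other phenyl ring with a methoxy group, would matter.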